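The source may report more compounds than this note shows. Statements on the series, on what has been measured and on what is new or still open speak of the compounds shown alone.

Two compounds share a core built around a naphthyl-bearing ring joined through a sulfur-linked acetamide. For the measured compounds named here, compound 1 `O=C(CSc1nncnc1-c1cccc2ccccc12)Nc1ccccc1[N+](=O)[O-]` in an ADME assay on MT4 cells (Homo sapiens) for cytotoxicity, read by MTT assay (on this read-out lower numbers stand for higher toxicity in this test and higher numbers for lower toxicity in this test), gives 142000 nM, the lowest of the two numbers known, while compound 2 `COC(=O)c1ccc(NC(=O)CSc2nncnc2-c2cccc3ccccc23)c(Br)c1` gives 173000 nM in this assay; the two lie within the scatter, so no order between them can be read. Compound 3 `O=C(CSc1nncnc1-c1cccc2ccccc12)Nc1ccc(Cl)cc1Cl` differs from compound 1 by 2,4-dichlorophenyl in place of 2-nitrophenyl on an amide-type nitrogen. Going by the values given here, with no measured step to lean on, a change of no more than the scatter is expected, as a 1.1-fold higher number from compound 1 to compound 3 (0.02 log units; within the scatter). Compound 3 is estimated at 150000 nM, between 70000 nM and 300000 nM.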

Compound 3, half-maximal cytotoxic concentration: 254000 nM
The estimate for compound 3 lay 1.7-fold (0.23 log units) below the measured number; the measured number falls inside the stated range.
By their numbers in this assay, from the lowest: compounds 1, 2 and 3 (each within the scatter of the next).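

For the compounds shown here, replacing 2-nitrophenyl with 2,4-dichlorophenyl on the amide-type nitrogen gives a 1.8-fold higher number from compound 1 to compound 3 (0.25 log units; within the scatter) in this assay and is the first comparison here of compounds that differ in one place. The nitro group can therefore give way to two chlorines at this position with no readable difference in this test. No measurement here accounts for this result. Still open, going by these compounds, is how a simple amine, a carboxylic acid or a longer chain on this nitrogen in place of the substituted phenyl ring would read.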